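A few compounds are considered here, and "the series" means these few. Any claim that something is new, unique, unknown or untested is made for them only; others in the source may bear on it.

Among the compounds with values here, of the two compounds measured in a functional assay on U-87MG ATCC cells for antiproliferative activity against U-87 MG (Homo sapiens), read by MTT assay, with a stated time of 72 h (on this read-out higher numbers stand for weaker inhibition and lower numbers for stronger inhibition), compound 2 `Cc1nn(C)c(Oc2cccc(Br)c2)c1/C=N\CCCCCCOc1cc2oc(=O)cc(C)c2cc1Cl` is the only one that carries a number: in this assay compound 2 gives 3610 nM. Compound 1 `Cc1nn(C)c(Oc2ccccc2F)c1/C=N\CCCCCCOc1cc2oc(=O)cc(C)c2cc1Cl` is reported only as a limit of the assay, > 25000 nM, as recorded in the limit of > 25000 nM in this assay, at which 1 of the 2 values shown sits. Within the data shown here, the single measured step, an at least 6.9-fold lower number from compound 1 to compound 2 (0.84 log units; beyond the scatter), shows that exchanging the ring on the oxygen of the shared core can move this assay beyond its scatter. Compound 3 `Cc1nn(C)c(Oc2ccc(OC(F)(F)F)cc2)c1/C=N\CCCCCCOc1cc2oc(=O)cc(C)c2cc1Cl` differs from compound 2 by 4-(trifluoromethoxy)phenyl in place of 3-bromophenyl on an oxygen on an aromatic ring. Among the measured compounds shown here, no measured pair contains the 4-(trifluoromethoxy)phenyl, so the step of an at least 6.9-fold lower number from compound 1 to compound 2 (0.84 log units; beyond the scatter) is the only guide, and it concerns a different exchange at the same oxygen. A step of modest size in either direction, or none beyond the scatter, is therefore expected in this assay. For compound 3 the expected value is 4500 nM, with a range from 1200 nM to 20000 nM. This estimate corresponds to an expected step of a 1.2-fold higher number from compound 2 to compound 3 (0.10 log units; within the scatter).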

Compound 3, half-maximal inhibitory concentration: 9620 nM
Compound 3: middle estimate off by 2.1-fold (0.33 log units), on the low side; measured number inside the range.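

With a second numbered compound at this oxygen, 4-(trifluoromethoxy)phenyl in place of 3-bromophenyl gives a 2.7-fold higher number from compound 2 to compound 3 (0.43 log units; beyond the scatter) in this assay, so two rings that both give a number still differ beyond the scatter. A number at this position is also not confined to the 3-bromophenyl, since 4-(trifluoromethoxy)phenyl in place of 2-fluorophenyl gives an at least 2.5-fold lower number from compound 1 to compound 3 (0.41 log units; beyond the scatter). Compound 1 stands only as a limit of the assay, so both steps from it are open on one side: the limit of > 25000 nM in this assay, at which 1 of the 3 values shown sits.

In the compounds shown, the substituent and its place on the phenyl ring change together, so neither can be read alone. From the compounds shown here alone, how an amine or a carboxylic acid on this ring, or a saturated cyclohexyl ring in place of the phenyl, would fare in this assay remains open.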